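Swapping the Hydroxypiperidine for a Sulfonyl Chain

The compounds below may be only part of what the source reports. "The series", "measured", "known", "first", "only" and "open" are said of these compounds alone.

Compound 1: `NCCCCCOc1ccc([C@H]2CC[C@]3(CC2)OOC2(O3)C3CC4CC(C3)CC2C4)cc1` — < 7 mL.min-1.g-1
Compound 2: `OC1(COc2ccc([C@H]3CC[C@]4(CC3)OOC3(O4)C4CC5CC(C4)CC3C5)cc2)CCNCC1` — 16 mL.min-1.g-1

In an ADME assay on microsomes from liver (Homo sapiens) for metabolic stability, read by LC-MS, tested at 1 uM (on this read-out lower numbers stand for slow clearance and higher numbers for fast clearance), compound 1 gives < 7 mL.min-1.g-1, which is a limit of the assay rather than a number. Going by the values given here, compound 2 gives 16 mL.min-1.g-1, the only plain number among the two results. Among the compounds with values here, the one measured step, an at least 2.2-fold higher number from compound 1 to compound 2 (0.35 log units; beyond the scatter), rests on that limit (the limit of < 7 mL.min-1.g-1 in this assay, at which 1 of the 2 values shown sits). Compound 3 `NCCS(=O)(=O)CCOc1ccc([C@H]2CC[C@]3(CC2)OOC2(O3)C3CC4CC(C3)CC2C4)cc1` differs from compound 2 by ((2-aminoethyl)sulfonyl)methyl in place of 4-hydroxypiperidin-4-yl on a saturated chain carbon bound to an oxygen on an aromatic ring. Within the data shown here, only that single step bears on this change, and it was at least modest, so for compound 3 a step of similar size is expected, most likely downward, as a 1.6-fold lower number from compound 2 to compound 3 (0.20 log units; within the scatter). Compound 3 is therefore estimated at 10 mL.min-1.g-1, between 5 mL.min-1.g-1 and 22 mL.min-1.g-1.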

Compound 3, intrinsic clearance in microsomes: 9 mL.min-1.g-1
For compound 3 the middle estimate is 1.1-fold (0.05 log units) above the measured one, and the stated range covers the measured number.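

Putting the open ((2-aminoethyl)sulfonyl)methyl chain in place of the 4-hydroxypiperidin-4-yl ring makes no clear difference in this assay: a 1.8-fold lower number from compound 2 to compound 3 (0.25 log units; within the scatter). The other new step, an at least 1.2-fold higher number from compound 1 to compound 3 (0.10 log units; that floor lies within the scatter), gives only a floor. The value of compound 1 is a limit of the assay, not a number: the limit of < 7 mL.min-1.g-1 in this assay, at which 1 of the 3 values shown sits.

Going by these compounds, what remains open is how much the amine at the chain end matters. A carboxylic acid there, or a longer chain between sulfonyl and amine, could shift clearance in either direction.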